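The source may report more compounds than this note shows. Statements on the series, on what has been measured and on what is new or still open speak of the compounds shown alone.

Compound 2 `Cc1cc(C)c(SCc2ncnc3c2ncn3[C@@H]2O[C@H](CO)[C@@H](O)[C@H]2O)c(C)c1` stands highest of the two numbers in hand: in an assay on isolated protein for binding affinity to Equilibrative nucleoside transporter 1 (Homo sapiens) (a lower number here means a stronger inhibitor, a higher number a weaker inhibitor), compound 2 gives 33100 nM, while compound 1 `OC[C@H]1O[C@@H](n2cnc3c(SCC4CCCCC4)ncnc32)[C@H](O)[C@@H]1O` gives 1550 nM, a gap that lies beyond the scatter. Compound 3 `OC[C@H]1O[C@@H](n2cnc3c(CSc4cccc(Br)c4)ncnc32)[C@H](O)[C@@H]1O` differs from compound 2 in one place, (3-bromophenyl in place of 2,4,6-trimethylphenyl on a sulfur). Going by the values given here, no measured pair shows this kind of change, so only the size of the step can be guessed. Compound 3 is expected to sit lower than compound 2, with the step of a 3.3-fold lower number from compound 2 to compound 3 (0.52 log units; beyond the scatter) modest but beyond the scatter. For compound 3 the estimate is 10000 nM in this assay, within a range from 3000 nM to 33000 nM.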

Compound 3, half-maximal inhibitory concentration: 363 nM
Estimate against measurement, compound 3: 28-fold (1.44 log units) above; the measured number lies below the stated range.
By their numbers in this assay, from the lowest: compound 3; then compound 1; then compound 2.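

In this assay, 3-bromophenyl in place of 2,4,6-trimethylphenyl on a sulfur gives a large step (a 91-fold lower number from compound 2 to compound 3 (1.96 log units; beyond the scatter)), so the aryl group at this place can move the number strongly. The change of ((3-bromophenyl)sulfanyl)methyl in place of (cyclohexylmethyl)sulfanyl on an aromatic carbon gives a modest step (a 4.3-fold lower number from compound 1 to compound 3 (0.63 log units; beyond the scatter)), leaving compound 3 with the lowest number of the three. No measurement given here accounts for either step. On these data alone, whether a plain phenyl, or a phenyl carrying chlorine or an amine in place of bromine, would match 3-bromophenyl remains open.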